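Trimming a Methoxy Group: Expected Cytotoxicity of Compound 4

This account rests on a few compounds, and the source may have more. Where it says the series, first, only, none or still open, it means among the compounds named here.

Measured compounds:
compound 1 `COc1cc(-c2cc(/C=C/C(=O)c3ccc(N)cc3)[nH]n2)cc(OC)c1OC` — 95%
compound 2 `COc1ccc(-c2cc(/C=C/C(=O)c3ccc(OC)c(OC)c3)[nH]n2)cc1` — 93%
compound 3 `COc1cc(-c2cc(/C=C/C(=O)c3ccc(Cl)c(Cl)c3)[nH]n2)cc(OC)c1OC` — 97%

In a functional assay on SK-MEL-5 cells (Homo sapiens) for cytotoxicity, read by sulforhodamine B assay, with a stated time of 48 h, tested at 0.1 uM (on this read-out lower numbers stand for a stronger effect and higher numbers for a weaker effect at the one concentration tested), compound 1 gives 95%, the second highest of the three numbers. Its nearest neighbour is compound 2 with 93%, and compound 3 lies furthest with 97%; both gaps are within the scatter. Going by the values given here, the one step that differs in a single place, a number 2 percentage points higher from compound 1 to compound 3 (within the scatter), changes the aryl on the carbonyl carbon and stays within the scatter.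

Compound 4 `COc1ccc(-c2cc(/C=C/C(=O)c3ccc(N)cc3)[nH]n2)cc1OC` is not yet measured. It differs from compound 1 by hydrogen in place of methoxy on an aromatic carbon, the methoxy leaving an aromatic carbon that is ortho to a methoxy group and meta to a large group. Among the compounds with values here, no measured step covers this exact change. Compound 2, which carries a different methoxy pattern on the same side of the shared core, shows a number within the scatter of compound 1, and the measured step on the other side was also flat. Compound 4 is therefore expected to show a number 1 percentage points lower from compound 1 to compound 4 (within the scatter), with a value estimated at 94% (range 84% to 100%).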

Compound 4, a percentage reported as activity, at one concentration (the size of the read-out at that concentration, not a potency): 95%
Compound 4: the middle estimate sits 1 percentage points below what was measured; the measured number falls inside the stated range.
By their numbers in this assay, from the lowest: compounds 2, 1, 4 and 3 (each within the scatter of the next).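

Going by these compounds alone, compound 4 gives the first single-place reading at this position in this assay: with hydrogen in place of methoxy on an aromatic carbon ortho to a methoxy group and meta to a large group, the result is no change at the digits printed from compound 1 to compound 4 (within the scatter) in this read-out at the one concentration tested. Compound 2 differs from compound 1 in more than one place and could not isolate this position, whereas this step shows that the methoxy group can be removed here, with the aminophenyl group held constant, without a change beyond the scatter. No available evidence bears on why the step is flat.

On these data alone, whether a hydroxyl, a fluorine or an ethoxy group at this position would behave the same way remains open. As far as these compounds go, it is also open whether this step would stay flat with the 3,4-dichlorophenyl group of compound 3 on the carbonyl carbon.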